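Replacing the methylpiperazine with an isopropylamine on the shared core

The source may hold more compounds than are shown below. What is called first, only, known or untested is meant among the compounds shown, and "the series" means these compounds.

Of the compounds shown here, two of a shared core have been measured in a functional assay on A549 cells (Homo sapiens) for cytotoxicity, read by MTT assay, with a stated time of 48 h; a lower number here means a stronger inhibitor, a higher number a weaker inhibitor. Compound 1 `CCCCNc1nc(Nc2ccccc2)nc2oc(C)c(C(=O)OCC)c12` gives 2700 nM. Compound 2 `CCOC(=O)c1c(C)oc2nc(Nc3cccc(C)c3)nc(N3CCN(C)CC3)c12` gives 5500 nM, the higher of the two numbers; its gap to compound 1 lies beyond the usual scatter. Compound 3 `CCOC(=O)c1c(C)oc2nc(Nc3cccc(C)c3)nc(NC(C)C)c12` has not yet been measured in this assay. It differs from compound 2 in one place: isopropylamino in place of 4-methylpiperazin-1-yl on an aromatic carbon. Among the compounds with values here, no step between measured compounds isolates this exchange, since compound 1 and compound 2 also differ elsewhere. Compound 1, which carries an open-chain alkylamino group at the same place, gives a number below that of compound 2, and on that basis a modest step toward a lower number is expected, though one that may stay within the scatter. Compound 3 is therefore estimated at 3500 nM, within a range of 1200 nM to 10000 nM. The expected step is a 1.6-fold lower number from compound 2 to compound 3 (0.20 log units; within the scatter).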

Compound 3, half-maximal inhibitory concentration: 8600 nM
For compound 3 the middle estimate is 2.5-fold (0.39 log units) below the measured one; the measured number falls inside the stated range.
By their numbers in this assay, from the lowest: compound 1; then compounds 2 and 3 (each within the scatter of the next).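

In this assay, the exchange of 4-methylpiperazin-1-yl for isopropylamino on this aromatic carbon, next to the ring nitrogen, can now be read by itself, as a 1.6-fold higher number from compound 2 to compound 3 (0.19 log units; within the scatter) shows. At this place, then, the shared core keeps its number within the scatter when the six-membered non-aromatic ring gives way to an open-chain group with fewer heavy atoms and a hydrogen-bond donor, so this single change gives no sign of a real shift in either direction. Nothing measured here explains that outcome. Still open, on these data alone, is whether a morpholine ring, a primary amine or a longer chain on this carbon would move the number beyond the scatter. The compounds shown also do not separate the effect of the methyl group on the (3-methylphenyl)amino group from that of the group at this place.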